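Urea substitution on the aminomethyl side chain

The source may report more compounds than this note shows. Statements on the series, on what has been measured and on what is new or still open speak of the compounds shown alone.

Three compounds of the series share one core and differ only in what sits on the aminomethyl nitrogen. Compound 1 `CCCCc1ccc(CN)c(=O)n1Cc1ccc(-c2ccccc2-c2nn[nH]n2)cc1` carries the free amine and in a functional assay (aorta) for antagonist activity, with Oryctolagus cuniculus as the target (a higher number here means a weaker inhibitor, a lower number a stronger inhibitor), compound 1 gives 20 nM. Compound 2 `CCCCc1ccc(CNC(=O)Nc2ccccc2)c(=O)n1Cc1ccc(-c2ccccc2-c2nn[nH]n2)cc1` carries a phenylcarbamoyl group there and in this assay compound 2 gives 30 nM. Compound 3 `CCCCNC(=O)NCc1ccc(CCCC)n(Cc2ccc(-c3ccccc3-c3nn[nH]n3)cc2)c1=O` carries a butylcarbamoyl group and in this assay compound 3 gives 10 nM, the low end of the three numbers: the gap to compound 1 is within the scatter, the gap to compound 2 is beyond it.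

The steps measured so far are small: a 2.0-fold lower number from compound 1 to compound 3 (0.30 log units; within the scatter), a 1.5-fold higher number from compound 1 to compound 2 (0.18 log units; within the scatter), and a 3.0-fold lower number from compound 2 to compound 3 (0.48 log units; beyond the scatter).

Compound 4 `CCCCc1ccc(CNC(=O)N(C)C)c(=O)n1Cc1ccc(-c2ccccc2-c2nn[nH]n2)cc1` is the next variation: dimethylamino in place of butylamino on a carbonyl carbon. The change removes the hydrogen-bond donor of the urea and shortens the chain. The steps from compound 1 to compound 3 and from compound 2 to compound 3 show that the group on the urea nitrogen shifts this assay only modestly, so an expected step of about a 2.0-fold higher number from compound 3 to compound 4 (0.30 log units; within the scatter) seems reasonable, toward a slightly higher number. In this assay compound 4 is therefore estimated at 20 nM, with a range from 8 nM to 50 nM.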

Compound 4, half-maximal inhibitory concentration: 2 nM
Compound 4: the middle estimate sits 10-fold (1.00 log units) above what was measured, and the stated range ends above it.
By their numbers in this assay, from the lowest: compound 4; then compounds 3, 1 and 2 (each within the scatter of the next, the first and the last beyond it).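

Among the ureas in this assay, dimethylcarbamoyl on the amine nitrogen is the first group to move the number clearly away from the free amine, with a 10-fold lower number from compound 1 to compound 4 (1.00 log units; beyond the scatter) and with phenylcarbamoyl and butylcarbamoyl both staying within the scatter of compound 1. Among these compounds, the group on this carbonyl carbon therefore matters more than the earlier steps showed: dimethylamino in place of butylamino gives a 5.0-fold lower number from compound 3 to compound 4 (0.70 log units; beyond the scatter) and dimethylamino in place of anilino gives a 15-fold lower number from compound 2 to compound 4 (1.18 log units; beyond the scatter) as the largest step in the set. This change removes the hydrogen-bond donor and shortens the group in a single move, so the two cannot be told apart here, and no measurement at hand accounts for the shift.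

Methylamino on the same carbonyl carbon would keep the donor on a short group and diethylamino would lack it on a longer one, so these two would separate the open question of donor against size. On these data alone, how cyclic groups such as pyrrolidinyl or morpholinyl behave at this carbonyl carbon also remains open.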